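The source may hold more compounds than are shown below. What is called first, only, known or untested is meant among the compounds shown, and "the series" means these compounds.

Measured compounds:
compound 1 `COc1ccc(N(C)c2ccnc(Cl)n2)cc1[N+](=O)[O-]` with 6120 nM
compound 2 `COc1ccc(N(C)c2ccnc(Cl)n2)cc1O` with 464 nM
compound 3 `COc1ccc(N(C)c2cc(C)nc(C)n2)cc1[N+](=O)[O-]` with 2990 nM

All three were tested in a functional assay on HepG2 cells (Homo sapiens) for antiproliferative activity, read by MTT assay, with a stated time of 48 h; on this read-out higher numbers stand for weaker inhibition and lower numbers for stronger inhibition. Compound 1 gives 6120 nM in this assay, and compound 2, which differs from it by hydroxy in place of nitro on an aromatic carbon, gives 464 nM; the step is a 13-fold lower number from compound 1 to compound 2 (1.12 log units; beyond the scatter). Compound 3 carries a different core, and the difference between its core and that of compound 1 is not broken down here; in this assay compound 3 gives 2990 nM, the second highest of the three numbers.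

Compound 4 `COc1ccc(N(C)c2cc(C)nc(C)n2)cc1O` has not yet been measured. It differs from compound 3 by hydroxy in place of nitro on an aromatic carbon. Within the data shown here, this is the same kind of change as the one from compound 1 to compound 2, though the surroundings are described slightly differently: in one case the place is meta to a large group, in the other meta to a group of 9 heavy atoms. Because that earlier change produced a 13-fold lower number from compound 1 to compound 2 (1.12 log units; beyond the scatter), a step of about the same direction and size is expected here, estimated as a 10-fold lower number from compound 3 to compound 4 (1.00 log units; beyond the scatter). On that basis compound 4 is expected to give about 300 nM in this assay, with a plausible range from 80 nM to 1200 nM.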

Compound 4, half-maximal inhibitory concentration: 112 nM
The estimate for compound 4 lay 2.7-fold (0.43 log units) above the measured number; low and high end bracket the measured number.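

In this assay, hydroxy in place of nitro on the core of compound 3 gives a 27-fold lower number from compound 3 to compound 4 (1.43 log units; beyond the scatter), so the change keeps its direction on the second core, and its size there cannot be told apart from its size on the first: the same change on two cores in this assay, a 13-fold lower number (1.12 log units; beyond the scatter) from compound 1 to compound 2 and a 27-fold lower number (1.43 log units; beyond the scatter) from compound 3 to compound 4, 2.0-fold (0.31 log units) apart, within the scatter of two such steps On these two cores, then, the step can be treated as one transferable change, and the larger figure on the core of compound 3 should not be read as a stronger effect. Among these compounds, this rests on only two matched pairs in a single cell assay, however, so it does not show that the step would hold on other cores, and it does not explain why the number falls.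

The compounds shown leave open how an amine or a carboxylic acid in the same place would compare with hydroxy and nitro. They also leave open whether the step would survive replacing the methoxy group with a longer chain, such as ethoxy.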